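Changing the group on the carbonyl carbon: compound 3

A few compounds are considered here, and "the series" means these few. Any claim that something is new, unique, unknown or untested is made for them only; others in the source may bear on it.

In a functional assay on HCT-116 cells (Homo sapiens) for antiproliferative activity (a lower number here means a stronger inhibitor, a higher number a weaker inhibitor), compound 1 `CC(=O)N1CCc2c(C)c3c(n2-c2ccc(C(N)=O)c(c2)N[C@@H](C)[C@H](C)C1)CC(C)(C)CC3=O` gives 24 nM and compound 2 `COCCC(=O)N1CCc2c(C)c3c(n2-c2ccc(C(N)=O)c(c2)N[C@@H](C)[C@H](C)C1)CC(C)(C)CC3=O` gives 38 nM, so compound 2 stands within the scatter of compound 1. Compound 3 `Cc1c2c(n3c1CCN(C(=O)C(C)(C)N)C[C@@H](C)[C@H](C)Nc1cc-3ccc1C(N)=O)CC(C)(C)CC2=O` is not yet measured. It carries 1-amino-1-methylethyl in place of 2-methoxyethyl on a carbonyl carbon, the difference from compound 2 being (1-amino-1-methylethyl in place of 2-methoxyethyl on a carbonyl carbon). Within the data shown here, the only measured step that bears on this change is a 1.6-fold higher number from compound 1 to compound 2 (0.20 log units; within the scatter), with methoxymethyl in place of hydrogen on a saturated chain carbon bound to a carbonyl carbon. Among the measured compounds shown here, no measured compound carries the entering group, so the evidence is thin. No step beyond the scatter is expected, and the estimated step is a 1.3-fold lower number from compound 2 to compound 3 (0.10 log units; within the scatter). The estimate for compound 3 in this assay is 30 nM, with an expected range of 10 nM to 90 nM.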

Compound 3, half-maximal inhibitory concentration: 25 nM
The estimate for compound 3 lay 1.2-fold (0.08 log units) above the measured number; the measured number falls inside the stated range.
By their numbers in this assay, from the lowest: compounds 1, 3 and 2 (each within the scatter of the next).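

In this assay, 1-amino-1-methylethyl in place of 2-methoxyethyl on the carbonyl carbon gives a 1.5-fold lower number from compound 2 to compound 3 (0.18 log units; within the scatter), and the same group in place of methyl gives a 1.0-fold higher number from compound 1 to compound 3 (0.02 log units; within the scatter). This position therefore now holds three different groups without a step beyond the scatter, including one that has a nitrogen instead of an oxygen and a hydrogen-bond donor where 2-methoxyethyl has none. No supporting measurement accounts for how closely these numbers agree.

From the compounds shown here alone, whether this agreement extends to a carboxylic acid, a longer chain or a phenyl ring on the same carbonyl carbon remains open. Also open, going by these compounds, is whether aminomethyl, which lacks the two methyl groups of 1-amino-1-methylethyl, would stay within the scatter of compound 3.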